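Bromo in place of chloro on a shared core

The source may hold more compounds than are shown below. What is called first, only, known or untested is meant among the compounds shown, and "the series" means these compounds.

Of the compounds shown here, two built on one core have numbers so far in a functional assay on MDA-MB-231 cells (Homo sapiens) for inhibition, read by MTT assay, with a stated time of 72 h; on this read-out lower numbers stand for stronger inhibition and higher numbers for weaker inhibition. Compound 1 `Cc1ccc2nc(-c3ccc4n[se]nc4c3)[nH]c2c1`, which carries methyl, gives 1000 nM. Compound 2 `Clc1ccc2nc(-c3ccc4n[se]nc4c3)[nH]c2c1`, which carries chloro at that place, gives 2100 nM, the higher of the two numbers and so the weaker inhibition of the pair.

Compound 3 `Brc1ccc2nc(-c3ccc4n[se]nc4c3)[nH]c2c1` has not yet been measured. It differs from compound 2 by bromo in place of chloro on an aromatic carbon, which is bromo in place of chloro on an aromatic carbon of a six-membered aromatic ring of carbon only, part of a fused or bridged system of two rings.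

Within the data shown here, the one measured step that bears on this change is a 2.1-fold higher number from compound 1 to compound 2 (0.32 log units; beyond the scatter), a modest step with chloro in place of methyl. Among the measured compounds shown here, no measured step involves bromo, so this single step is only a loose guide, and an expectation resting on it stays small. The expected step is a 1.1-fold lower number from compound 2 to compound 3 (0.02 log units; within the scatter), with nothing beyond the scatter anticipated in either direction. Compound 3 is estimated at 2000 nM, with an expected range of 1000 nM to 4000 nM.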

Compound 3, half-maximal inhibitory concentration: 1300 nM
Estimate against measurement, compound 3: 1.5-fold (0.19 log units) above, within the range that was stated.
By their numbers in this assay, from the lowest: compounds 1, 3 and 2 (each within the scatter of the next, the first and the last beyond it).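

At this aromatic carbon, the exchange of chloro for bromo in this assay gives a 1.6-fold lower number from compound 2 to compound 3 (0.21 log units; within the scatter) and so does not separate the two halogens, and bromo does not separate from methyl either, with a 1.3-fold higher number from compound 1 to compound 3 (0.11 log units; within the scatter) as the step. Compound 3 therefore lies within the scatter of both compound 1 and compound 2, even though the earlier step of a 2.1-fold higher number from compound 1 to compound 2 (0.32 log units; beyond the scatter) had set those two apart, so that modest gap now has a compound with no clear separation from either end. Nothing at hand gives a reason for these numbers. Methyl, chloro and bromo are the only groups compared at this place, so the series does not show whether an amine, a carboxylic acid or a longer chain on the same aromatic carbon would stay close to these numbers or move well away from them. Also open, going by these compounds, is whether the closeness of these three compounds would hold in other cells or after changes elsewhere on the shared core.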